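The compounds below may be only part of what the source reports. "The series", "measured", "known", "first", "only" and "open" are said of these compounds alone.

Compound 1 `CC(C)(C)c1cc(/C=C/C(=O)NCCC2CCN(Cc3ccccc3F)CC2)cc(C(C)(C)C)c1O` gives 60200 nM in an assay on isolated protein for inhibition of Amine oxidase [flavin-containing] A (Homo sapiens), read by fluorescence, with stated times of 15 min and 20 min; a higher number here means a weaker inhibitor, a lower number a stronger inhibitor.
Compound 2 `CC(C)(C)c1cc(/C=C/C(=O)NCCC2CCN(Cc3ccc(F)cc3F)CC2)cc(C(C)(C)C)c1O` gives 70600 nM in this assay.

Among the measured compounds shown here, compound 2 stands within the scatter of compound 1, the only other measured compound, since the step of a 1.2-fold higher number from compound 1 to compound 2 (0.07 log units; within the scatter) does not exceed it. Compound 3 `CC(C)(C)c1cc(/C=C/C(=O)NCCC2CCN(Cc3ccc(F)c(F)c3)CC2)cc(C(C)(C)C)c1O` differs from compound 2 by 3,4-difluorophenyl in place of 2,4-difluorophenyl on a saturated chain carbon bound to an amine nitrogen in a ring. For the measured compounds named here, no measured step moves a fluorine within the ring; the one measured step, a 1.2-fold higher number from compound 1 to compound 2 (0.07 log units; within the scatter), adds a fluorine and stays within the scatter. For compound 3 a step of a 1.1-fold lower number from compound 2 to compound 3 (0.04 log units; within the scatter) is therefore expected, with nothing beyond the scatter. The estimate for compound 3 is 65000 nM, expected to fall between 30000 nM and 140000 nM.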

Compound 3, half-maximal inhibitory concentration: 64500 nM
For compound 3 the middle estimate is 1.0-fold (0.00 log units) above the measured one, within the range that was stated.
By their numbers in this assay, from the lowest: compounds 1, 3 and 2 (each within the scatter of the next).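

Rearranging the two fluorines on the benzyl group gives a 1.1-fold lower number from compound 2 to compound 3 (0.04 log units; within the scatter) in this assay, so this position now has a measured rearrangement of fluorines as well as an added fluorine. The comparison with the single fluorine of 2-fluorophenyl, a 1.1-fold higher number from compound 1 to compound 3 (0.03 log units; within the scatter), also stays within the scatter. No available evidence bears on this result.

The compounds shown leave open whether a benzyl group without fluorine, or one carrying a methoxy group or a nitrile, would read differently at this position.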